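The compounds below may be only part of what the source reports. "The series", "measured", "known", "first", "only" and "open" are said of these compounds alone.

Going by the values given here, in a functional assay on J774.A1 cells (Mus musculus) for inhibition, read by Griess assay, with stated times of 1 h and 24 h (a lower number here means a stronger inhibitor, a higher number a weaker inhibitor), compound 3 `O=C1CC(c2ccccc2OCc2cccc(F)c2)Oc2ccccc21` reads 13200 nM and holds the lowest of the three numbers so far. Compound 1 `CC(C)COc1ccccc1C1CC(=O)c2ccccc2O1` gives 33200 nM and compound 2 `C=CCOc1ccccc1C1CC(=O)c2ccccc2O1` gives 38600 nM as the two higher values. Compound 4 `COCOc1ccccc1C1CC(=O)c2ccccc2O1` puts methoxy in place of 3-fluorophenyl on a saturated chain carbon bound to an oxygen on an aromatic ring, a change counted as methoxy in place of 3-fluorophenyl on a saturated chain carbon bound to an oxygen on an aromatic ring and reading, one bond further out, as 3-fluorobenzyl to methoxymethyl. Among the compounds with values here, two measured steps bear on it most directly: a 2.5-fold lower number from compound 1 to compound 3 (0.40 log units; beyond the scatter) and a 2.9-fold lower number from compound 2 to compound 3 (0.47 log units; beyond the scatter) are both modest and each brings in the 3-fluorophenyl, whereas a 1.2-fold higher number from compound 1 to compound 2 (0.07 log units; within the scatter) stays within the scatter. Like compound 1 and compound 2, compound 4 has no ring in this group, so the modest advantage of compound 3 is expected to disappear. In this assay the expected change is a 2.5-fold higher number from compound 3 to compound 4 (0.40 log units; beyond the scatter) toward a weaker inhibitor. Compound 4 is estimated at 33000 nM with an expected range of 15000 nM to 70000 nM in this assessment.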

Compound 4, half-maximal inhibitory concentration: 35200 nM
The estimate for compound 4 lay 1.1-fold (0.03 log units) below the measured number; the measured number falls inside the stated range.
By their numbers in this assay, from the lowest: compound 3; then compounds 1, 4 and 2 (each within the scatter of the next).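

In this assay, the change from 3-fluorobenzyl to methoxymethyl gives a 2.7-fold higher number from compound 3 to compound 4 (0.43 log units; beyond the scatter), so the lower number of compound 3 does not carry over to this ring-free group, which adds a hydrogen-bond acceptor. Among the ring-free groups at this position, the new acceptor brings no readable change: a 1.1-fold lower number from compound 2 to compound 4 (0.04 log units; within the scatter) and a 1.1-fold higher number from compound 1 to compound 4 (0.03 log units; within the scatter) both stay within the scatter. Across these four compounds, the only one with a ring in this group has the only separated number, though no measurement shown here explains that difference.

With 3-fluorobenzyl as the only ring-bearing group shown, the ring and its fluorine cannot be told apart, and a plain benzyl group would separate them. As far as these compounds go, how an amine or a carboxylic acid at the end of this chain would read also remains open.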